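Phenyl to 3-chloropyridin-2-yl on the amide nitrogen

The source may report more compounds than this note shows. Statements on the series, on what has been measured and on what is new or still open speak of the compounds shown alone.

In a functional assay on U-87MG ATCC cells for inhibition, with U-87 MG (Homo sapiens) as the target, read by MTT assay, with a stated time of 72 h (on this read-out lower numbers stand for stronger inhibition and higher numbers for weaker inhibition), compound 1 `Cc1noc(C)c1-c1cnc(N)c(Oc2ccc(C(=O)Nc3ccccc3)cc2)n1` gives 26600 nM. Compound 2 `Cc1noc(C)c1-c1cnc(N)c(Oc2ccc(C(=O)Nc3ccccc3Cl)cc2)n1` gives 60500 nM, and compound 3 `Cc1noc(C)c1-c1cnc(N)c(Oc2ccc(C(=O)Nc3ccc(Cl)cn3)cc2)n1` gives 45600 nM. Compound 1 therefore stands clearly apart only from compound 2, and it sits level with compound 3 within the usual scatter.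

Compound 4 `Cc1noc(C)c1-c1cnc(N)c(Oc2ccc(C(=O)Nc3ncccc3Cl)cc2)n1` has 3-chloropyridin-2-yl in place of phenyl on an amide-type nitrogen. Among the measured compounds shown here, no measured compound carries exactly this group. The nearest guides are a 2.3-fold higher number from compound 1 to compound 2 (0.36 log units; beyond the scatter), which is modest, and a 1.7-fold higher number from compound 1 to compound 3 (0.23 log units; within the scatter), which stays within the scatter. Both point upward, so a small upward step of similar size is expected in this assay. The estimated step is a 1.9-fold higher number from compound 1 to compound 4 (0.27 log units; within the scatter). Compound 4 is expected at 50000 nM, with an estimated range of 25000 nM to 100000 nM.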

Compound 4, half-maximal inhibitory concentration: 45600 nM
Estimate against measurement, compound 4: 1.1-fold (0.04 log units) above; measured number inside the range.
By their numbers in this assay, from the lowest: compounds 1, 3, 4 and 2 (each within the scatter of the next, the first and the last beyond it).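

In this assay, swapping the ring for 3-chloropyridin-2-yl gives a 1.7-fold higher number from compound 1 to compound 4 (0.23 log units; within the scatter), and moving from 5-chloropyridin-2-yl to this group gives no change at the digits printed from compound 3 to compound 4 (within the scatter), so these two chloropyridinyl groups cannot be told apart here. Replacing 2-chlorophenyl with 3-chloropyridin-2-yl gives a 1.3-fold lower number from compound 2 to compound 4 (0.12 log units; within the scatter), which places compound 4 within the scatter of all three earlier compounds. Nothing shown explains these numbers. Still open, on these data alone, is whether a non-aromatic group on the amide nitrogen, such as a cyclohexyl ring or a short chain ending in an amine, would stand clearly apart from compound 1.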